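Taking the phenyl off compound 3

The compounds below may be only part of what the source reports. "The series", "measured", "known", "first", "only" and "open" are said of these compounds alone.

Going by the values given here, in a functional assay on A549 cells (Homo sapiens) for antiproliferative activity, read by MTT assay, with a stated time of 48 h (on this read-out lower numbers stand for stronger inhibition and higher numbers for weaker inhibition), compound 3 `Cn1cc(C2=C(c3nn(CCCn4ccnc4)c4ncccc34)C(=O)N(c3ccccc3)C2=O)c2ccccc21` gives 1560 nM, the only actual number among the measured compounds. Compound 1 `Cn1cc(C2=C(c3nn(CCCn4cncn4)c4ncccc34)C(=O)NC2=O)c2ccccc21` reads > 100000 nM, which is a limit of the assay and not a number. Compound 2 `Cn1cc(C2=C(c3nn(CCCn4cccc4)c4ncccc34)C(=O)NC2=O)c2ccccc21` reads > 100000 nM, which is also a limit. Among the compounds with values here, the only measured step is a step that the two limits leave unreadable from compound 1 to compound 2, and it lies at another place in the molecule, so it does not size the change at issue here.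

Compound 4 `Cn1cc(C2=C(c3nn(CCCn4ccnc4)c4ncccc34)C(=O)NC2=O)c2ccccc21` differs from compound 3 as follows: hydrogen in place of phenyl on an amide-type nitrogen in a ring, with hydrogen in place of phenyl on an amide-type nitrogen in a ring. The nearest guide is that compounds 1 and 2 also carry hydrogen on that nitrogen and stand at the limit of > 100000 nM in this assay, at which 2 of the 3 values shown sit, although the group at the end of their chain differs from that of compound 4. A clear weakening in this assay is therefore expected, a 19-fold higher number from compound 3 to compound 4 (1.28 log units; beyond the scatter), and the reading may reach the limit. For compound 4 the estimated value is 30000 nM, with an expected range of 4000 nM to 100000 nM.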

Compound 4, half-maximal inhibitory concentration: > 100000 nM
Compound 4: a limit, no number; the forecaster's own chance of this, stated with the estimate: 45%; at least 3.3-fold (0.52 log units) between middle value and limit.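

In this assay, going by these compounds alone, putting hydrogen in place of phenyl on the amide-type nitrogen in a ring, with the 1H-imidazol-1-yl chain unchanged, gives an at least 64-fold higher number from compound 3 to compound 4 (1.80 log units; beyond the scatter), so this position now has a measured step of its own, which the earlier compounds could not provide. The value of compound 4, > 100000 nM, is a limit of the assay and not a number. Among the compounds shown, the hydrogen on this nitrogen is found in compound 1, compound 2 and compound 4, and all of them read at the limit, while only compound 3 carries phenyl there and gives a number: the limit of > 100000 nM in this assay, at which 3 of the 4 values shown sit.

On these data alone, the steps among compound 1, compound 2 and compound 4 at the end of the chain cannot be read, so the part played by that group with hydrogen on the nitrogen stays open. As far as these compounds go, it also stays open whether phenyl itself matters or whether a methyl or benzyl group on that nitrogen would give a number too.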